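Pyridin-3-yl for Thiophen-2-yl on a Thiazolyl Hydrazone

This account rests on a few compounds, and the source may have more. Where it says the series, first, only, none or still open, it means among the compounds named here.

Compound 1 `C/C(=N/Nc1nc(-c2ccc(C#N)cc2)cs1)c1cccs1` was tested in an in vitro assay on BTI-TN-5B1-4 cells for inhibition of Amine oxidase [flavin-containing] A (Homo sapiens), read by Amplex Red, with a stated time of 15 min, tested at 100 uM (a higher number here means more inhibition at the concentration tested (going by the name of the read-out), a lower number less inhibition), where compound 1 gives 40%. A second compound, compound 2 `N#Cc1ccc(-c2csc(N/N=C\c3cccnc3)n2)cc1`, was tested in the same way, and compound 2 gives 40%, so compound 1 stands level with compound 2 at the digits shown, the difference lying within the scatter. For the measured compounds named here, no step between two measured compounds that differ in a single place has been recorded, so the account has no measured step to lean on. Compound 3 `C/C(=N/Nc1nc(-c2ccc(C#N)cc2)cs1)c1cccnc1` has not yet been measured. Its structure departs from compound 1 in one place: pyridin-3-yl in place of thiophen-2-yl on a carbon with a double bond to nitrogen. With compound 1 at 40% and compound 2 at 40%, both in this assay, the step of no change at the digits printed from compound 1 to compound 3 (within the scatter) is expected to stay within the scatter in either direction. Compound 3 is therefore estimated to give 40% in this assay, with a range from 25% to 55%.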

Compound 3, a percentage reported as inhibition, at one concentration (the size of the read-out at that concentration, not a potency): 40%
The estimate for compound 3 equals the measured number at the digits printed; the measured number falls inside the stated range.
By their numbers in this assay, from the lowest: compounds 1, 2 and 3 (each within the scatter of the next).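

In this assay, for the compounds shown here, pyridin-3-yl in place of thiophen-2-yl on a carbon with a double bond to nitrogen gives no change at the digits printed from compound 1 to compound 3 (within the scatter) and is the first single-place step available for these compounds. At this position, a six-membered aromatic ring with 1 hetero atom therefore gives a reading that cannot be told apart from that of a five-membered aromatic ring with 1 hetero atom, at the one concentration tested. No measured evidence bears on why the reading holds across this exchange.

On these data alone, both groups compared here are aromatic rings, so the effect of an amine, a carboxylic acid or a longer chain on this same carbon remains open. A reading at one concentration also leaves open whether compound 1 and compound 3 would match in potency.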